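Chain Shortening Across Two Double-Bond Isomers

This account rests on a few compounds, and the source may have more. Where it says the series, first, only, none or still open, it means among the compounds named here.

Compound 2 `CC(C)(CCCC/C=C(/c1ccccc1)c1cccnc1)C(=O)O` gives 38 nM in an assay (Equus caballus) for inhibition of Thromboxane-A synthase (Homo sapiens), using microsomes; a lower number here means a stronger inhibitor, a higher number a weaker inhibitor. Compound 3 `CC(C)(CCCC/C=C(\c1ccccc1)c1cccnc1)C(=O)O` differs from compound 2 in that (the two compounds have the same atoms and bonds and differ only in configuration as drawn: 1 of 1 stereo elements differ; a double bond is drawn Z in compound 2 and E in compound 3); compound 3 gives 45 nM in this assay, and the step of a 1.2-fold higher number from compound 2 to compound 3 (0.07 log units; within the scatter) is not read as a change, resting on (the fact that compounds 2 and 3 differ only in the configuration as drawn). Compound 1 `O=C(O)CCC/C=C(/c1ccccc1)c1cccnc1` gives 280 nM in this assay. The change from compound 2 to compound 1 is carboxy in place of 2-carboxy-2-methylpropyl on a saturated chain carbon, three bonds along the chain from a double-bonded chain carbon, and it made a step of a 7.4-fold higher number from compound 2 to compound 1 (0.87 log units; beyond the scatter). Compound 4 `O=C(O)CCC/C=C(\c1ccccc1)c1cccnc1` is not yet measured in this assay. Compound 4 differs from compound 3 by carboxy in place of 2-carboxy-2-methylpropyl on a saturated chain carbon, three bonds along the chain from a double-bonded chain carbon, the same change as from compound 2 to compound 1. For compound 4 the expected step is a 7.1-fold higher number from compound 3 to compound 4 (0.85 log units; beyond the scatter), matching the earlier step of a 7.4-fold higher number from compound 2 to compound 1 (0.87 log units; beyond the scatter). Compound 4 is therefore estimated at 320 nM in this assay, expected between 130 nM and 800 nM.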

Compound 4, half-maximal inhibitory concentration: 30 nM
Estimate against measurement, compound 4: 11-fold (1.03 log units) above; measured number below the stated range.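

In this assay, replacing 2-carboxy-2-methylpropyl with carboxy did not carry over from one double-bond isomer to the other, the new step being a 1.5-fold lower number from compound 3 to compound 4 (0.18 log units; within the scatter): the same change on two cores in this assay, a 7.4-fold higher number (0.87 log units; beyond the scatter) from compound 2 to compound 1 and a 1.5-fold lower number (0.18 log units; within the scatter) from compound 3 to compound 4, 11-fold (1.04 log units) apart, beyond the scatter of two such steps. The configuration as drawn separates the two carboxy compounds, with a 9.3-fold lower number from compound 1 to compound 4 (0.97 log units; beyond the scatter), but not the two 2-carboxy-2-methylpropyl compounds: the fact that compounds 1 and 4 differ only in the configuration as drawn. These results rest on a single pair of cores, so they do not show how the change would behave on any other core, nor why the two steps differ.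

The compounds shown leave open whether a longer chain without the two methyl groups would follow the Z or the E isomers. They also leave open how a tetrazole in place of the carboxylic acid would behave.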